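The source may hold more compounds than are shown below. What is called first, only, known or untested is meant among the compounds shown, and "the series" means these compounds.

In a functional assay on cells for antagonist activity at D(4) dopamine receptor (Homo sapiens), read by TR-FRET and cAMP accumulation, with a stated time of 30 min (a lower number here means a stronger inhibitor, a higher number a weaker inhibitor), compound 1 `CCc1cccc(NC(=O)CN2CCN(c3ccccn3)CC2)c1` gives 1310 nM, the lowest of the three numbers shown. Compound 2 `CCc1cccc(NC(=O)CN2CCN(c3ccc(Cl)cn3)CC2)c1` gives 7060 nM in this assay, and compound 3 `Cc1cccc(NC(=O)CCN2CCC(c3ccccn3)CC2)c1` gives 6340 nM. Going by the values given here, the only single-point step measured, a 5.4-fold higher number from compound 1 to compound 2 (0.73 log units; beyond the scatter), concerns a change at a different part of the structure. Compound 4 `Cc1cccc(NC(=O)CN2CCN(c3ccccn3)CC2)c1` differs from compound 1 by hydrogen in place of methyl on a saturated chain carbon bound to an aromatic carbon. Among the compounds with values here, no measured step bears directly on this change; compound 3 also carries the methyl, but its structure differs from that of compound 1 in more than one place, so its number offers no clean comparison. A small step is therefore expected, a 1.4-fold higher number from compound 1 to compound 4 (0.14 log units; within the scatter), with no firm direction. Compound 4 is expected to give 1800 nM in this assay, between 700 nM and 5000 nM.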

Compound 4, half-maximal inhibitory concentration: 82.7 nM
Compound 4: middle estimate off by 22-fold (1.34 log units), on the high side; measured number below the stated range.
By their numbers in this assay, from the lowest: compound 4; then compound 1; then compounds 3 and 2 (each within the scatter of the next).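

In this assay, going from 3-ethylphenyl to 3-methylphenyl gives a 16-fold lower number from compound 1 to compound 4 (1.20 log units; beyond the scatter), a large step for the loss of a single carbon. Going by these compounds alone, the earlier step, a 5.4-fold higher number from compound 1 to compound 2 (0.73 log units; beyond the scatter), lay at a different part of the structure, so this is the first sign that the group on this saturated chain carbon strongly affects the number. Nothing available explains the size of this step. The compounds shown leave open how a longer chain such as propyl, or a methoxy group, would behave at this place. They also leave open whether chloro would raise the number of compound 4 as it did that of compound 1.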